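Aryl piperazine dithiocarbamates: a ring substituent change on compound 2

The compounds below may be only part of what the source reports. "The series", "measured", "known", "first", "only" and "open" are said of these compounds alone.

Measured compounds in a functional assay on MGC-803 cells (Homo sapiens) for antiproliferative activity, read by CCK-8 assay, with a stated time of 72 h, tested at 2 uM; on this read-out lower numbers stand for a weaker effect and higher numbers for a stronger effect at the one concentration tested:
- compound 1 `Nc1ccccc1NC(=O)c1ccc(CSC(=S)N2CCN(c3ccccc3)CC2)cc1` gives 42.3%
- compound 2 `Nc1ccccc1NC(=O)c1ccc(CSC(=S)N2CCN(c3cccnc3)CC2)cc1` gives 27.6%
- compound 3 `CN(C(=S)SCc1ccc(C(=O)Nc2ccccc2N)cc1)c1cccnc1` gives 46.1%

Compound 2 stands lowest of the three numbers in this assay; compound 1 lies nearest, and compound 3 furthest, both beyond the scatter above it.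

The untested compound 4 `Nc1ccccc1NC(=O)c1ccc(CSC(=S)N2CCN(Cc3ccncc3)CC2)cc1` differs from compound 2 in one place: (pyridin-4-yl)methyl in place of pyridin-3-yl on an amine nitrogen in a ring.

Within the data shown here, the only measured step at the same position is a number 14.7 percentage points lower from compound 1 to compound 2 (beyond the scatter). That step shows the ring nitrogen substituent does move the read-out, but it concerns phenyl against pyridin-3-yl, not the (pyridin-4-yl)methyl group that enters here, so it gives direction only loosely. Among the measured compounds shown here, compound 3 carries pyridin-3-yl on a different nitrogen and forms no single-change pair with compound 2 or compound 4; its value and that of compound 2 merely bracket the range seen so far.

For the measured compounds named here, with no close precedent, a step of modest size in either direction is expected, most likely a small rise back toward compound 1, estimated as a number 7.4 percentage points higher from compound 2 to compound 4 (within the scatter). Compound 4 is therefore expected at 35%, with a range of 18% to 55%.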

Compound 4, a percentage reported as inhibition, at one concentration (the size of the read-out at that concentration, not a potency): 18.4%
Compound 4: middle estimate off by 16.6 percentage points, on the high side; measured number inside the range.
By their numbers in this assay, from the lowest: compounds 4 and 2 (each within the scatter of the next); then compounds 1 and 3 (each within the scatter of the next).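

In this assay the change to (pyridin-4-yl)methyl gives a number 9.2 percentage points lower from compound 2 to compound 4 (within the scatter) and so does not set this group apart from pyridin-3-yl at this position. Set against phenyl, the same group gives a number 23.9 percentage points lower from compound 1 to compound 4 (beyond the scatter) and thus does not restore the number seen with phenyl, leaving both pyridine-bearing groups apart from phenyl across these three compounds. No measurement at hand accounts for this behaviour.

Going by these compounds, compound 4 differs from compound 2 in both the added carbon link and the place of the ring nitrogen, so the share of each in the step stays open. On these data alone, a benzyl group or a directly attached pyridin-4-yl on this nitrogen would separate the two, and how a non-aromatic group such as cyclohexyl would read remains open as well.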